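A few compounds are considered here, and "the series" means these few. Any claim that something is new, unique, unknown or untested is made for them only; others in the source may bear on it.

Three compounds have so far been examined in an ADME assay on ECV-304 cells (Homo sapiens) for cytotoxicity, read by MTT assay, with a stated time of 72 h; a lower number here means a stronger inhibitor, a higher number a weaker inhibitor: compound 1 `COc1ccc(C2=C(c3cc(OC)c(OC)c(OC)c3)C(=O)CC2C)cc1C(=O)O`, compound 2 `C=CCOc1cc(C2=C(c3cc(OC)c(OC)c(OC)c3)C(=O)C(O)C2)ccc1OC` and compound 3 `COc1cc(C2=C(c3cc(C)c(OC)c(C)c3)C(O)CC2=O)cc(OC)c1OC`. Compound 1 gives > 100 ug/mL, which is a limit of the assay and not a number. Compound 2 gives > 100 ug/mL, again only a limit. Compound 3 gives > 100 ug/mL, likewise a limit. Compound 2 therefore stands where the whole set stands, as the limit of > 100 ug/mL in this assay, at which 3 of the 3 values shown sit, shows, and no pair of measured compounds offers a step to reason from.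

The next compound to be tested is compound 4 `COc1ccc(C2=C(c3cc(OC)c(OC)c(OC)c3)C(=O)C(O)C2)cc1Cl`. It differs from compound 2 in one place: chloro in place of allyloxy on an aromatic carbon. Chloro takes the place of allyloxy on an aromatic carbon, ortho to a methoxy group, and the rest of the structure is unchanged. With every reading so far at the limit, the data give no measured size for such a change. If any movement is seen, the expected direction is toward stronger inhibition, and a further reading at the same limit would be no surprise. The estimated step is an at least 3.3-fold lower number from compound 2 to compound 4 (0.52 log units; beyond the scatter). Compound 4 is estimated at 30 ug/mL, with an expected range from 1 ug/mL to 100 ug/mL.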

Compound 4, half-maximal inhibitory concentration: 20 ug/mL
Estimate against measurement, compound 4: 1.5-fold (0.18 log units) above; the measured number falls inside the stated range.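

In this assay, among these compounds, replacing allyloxy with chloro on an aromatic carbon, ortho to a methoxy group, gives an at least 5.0-fold lower number from compound 2 to compound 4 (0.69 log units; beyond the scatter), so this position is the first place in the set where a single change is seen to move the reading. From the compounds shown here alone, compound 2 gives > 100 ug/mL, which is a limit and not a number, so the size of this step has only a lower bound and its true size remains unknown. Compound 4 is also the only compound shown with a measured number, so the change gives the first reading that can be placed on a scale at all, against a background otherwise held at one value: the limit of > 100 ug/mL in this assay, at which 3 of the 4 values shown sit.

This single pair cannot separate the loss of allyloxy, with its 4 heavy atoms and hydrogen-bond acceptor, from the arrival of chloro, and it does not show how a bromo, a methyl or an amine on the same aromatic carbon would read. It also leaves open whether chloro in this place would have the same effect on a different core, such as that of compound 3.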